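Isopropyl to cyclohexyl on the amine nitrogen of compound 3

A few compounds are considered here, and "the series" means these few. Any claim that something is new, unique, unknown or untested is made for them only; others in the source may bear on it.

Three compounds of the shared core are measured. Compound 1 `Cc1ccc(S(=O)(=O)/N=C(/CCNC2=CC(=O)c3ccccc3C2=O)Nc2ccc(F)cc2)cc1` gives 9330 nM in a functional assay on A549 cells (Homo sapiens) for cytotoxicity, read by MTT assay, with a stated time of 48 h; a higher number here means a weaker inhibitor, a lower number a stronger inhibitor. Compound 2 `Cc1ccc(S(=O)(=O)/N=C(/CCNC2=CC(=O)c3ccccc3C2=O)Nc2ccccc2I)cc1` gives 24700 nM in this assay. Compound 3 `Cc1ccc(S(=O)(=O)/N=C(/CCNC2=CC(=O)c3ccccc3C2=O)NC(C)C)cc1` gives 44300 nM in this assay, the highest of the three numbers; its steps are a 4.7-fold higher number from compound 1 to compound 3 (0.68 log units; beyond the scatter) and a 1.8-fold higher number from compound 2 to compound 3 (0.25 log units; within the scatter), the latter within the scatter, so compound 3 and compound 2 cannot be ordered.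

Compound 4 `Cc1ccc(S(=O)(=O)/N=C(/CCNC2=CC(=O)c3ccccc3C2=O)NC2CCCCC2)cc1` differs from compound 3 by cyclohexyl in place of isopropyl on an amine nitrogen. Going by the values given here, no measured step swaps one non-aromatic group for another; the steps that reach compound 3 (a 4.7-fold higher number from compound 1 to compound 3 (0.68 log units; beyond the scatter), a 1.8-fold higher number from compound 2 to compound 3 (0.25 log units; within the scatter)) each replace an aryl group with isopropyl and give modest or scatter-level rises. Cyclohexyl keeps the amine nitrogen carrying a non-aromatic group, so the expected step of a 1.1-fold lower number from compound 3 to compound 4 (0.04 log units; within the scatter) in this assay is none beyond the scatter, direction uncertain. Compound 4 is therefore estimated at 40000 nM, in the range 15000 nM to 110000 nM.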

Compound 4, half-maximal inhibitory concentration: 14700 nM
The estimate for compound 4 lay 2.7-fold (0.43 log units) above the measured number; measured number below the stated range.
By their numbers in this assay, from the lowest: compounds 1, 4, 2 and 3 (each within the scatter of the next, the first and the last beyond it).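

In this assay a swap between two non-aromatic groups on this amine nitrogen matters: a 3.0-fold lower number from compound 3 to compound 4 (0.48 log units; beyond the scatter), so the rises seen on going from an aryl group to isopropyl do not extend to every non-aromatic group. Compound 4 cannot be ordered against the aryl compounds, as a 1.7-fold lower number from compound 2 to compound 4 (0.23 log units; within the scatter) and a 1.6-fold higher number from compound 1 to compound 4 (0.20 log units; within the scatter) are both within the scatter, so an aromatic ring on this nitrogen is not needed for a number level with theirs. No measurement available explains the step from isopropyl to cyclohexyl.

Open, from the compounds shown here alone, is whether the number keeps falling as carbon is added to a non-aromatic group here, which a cyclopentyl or a cycloheptyl group would test. Also open, going by these compounds, is how a hydroxyl or an amine on the cyclohexyl ring would read in this assay.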